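Methyl for hydrogen on the hydroxy oxygen, second pair

The source may report more compounds than this note shows. Statements on the series, on what has been measured and on what is new or still open speak of the compounds shown alone.

Measured in a functional assay on MCF7 cells (Homo sapiens) for inhibition, read by sulforhodamine B assay, with a stated time of 48 h, tested at 10 uM; a lower number here means a stronger effect, a higher number a weaker effect of the compound at the concentration tested:
compound 1, `O=C(Nc1cccc(-n2cc(-c3ccncc3)c(-c3cc(O)cc(Cl)c3)n2)c1)Nc1ccc(Cl)c(Cl)c1`, gives 2.74%
compound 2, `COc1cc(Cl)cc(-c2nn(-c3cccc(NC(=O)Nc4ccc(Cl)c(Cl)c4)c3)cc2-c2ccncc2)c1`, gives 4.66%
compound 3, `O=C(Nc1cccc(-n2cc(-c3ccncc3)c(-c3cc(O)cc(Cl)c3)n2)c1)c1cc(C(F)(F)F)cc(C(F)(F)F)c1`, gives 23%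

Compound 1 and compound 2 differ only by methyl in place of hydrogen on an oxygen on an aromatic ring. The step of a number 1.9 percentage points higher from compound 1 to compound 2 (within the scatter) is within the scatter, so this change left the read-out in this assay essentially unmoved in that pair. Compound 3 gives the highest number of the three; the difference between its core and the core of compound 1 is not broken down here.

Compound 4, `COc1cc(Cl)cc(-c2nn(-c3cccc(NC(=O)c4cc(C(F)(F)F)cc(C(F)(F)F)c4)c3)cc2-c2ccncc2)c1`, is not yet measured. It differs from compound 3 by methyl in place of hydrogen on an oxygen on an aromatic ring, the same change, at the same place, as from compound 1 to compound 2. On that single precedent, a step of similar size is expected: a number 2 percentage points higher from compound 3 to compound 4 (within the scatter). Among the compounds with values here, compound 4 is therefore estimated at 25% in this assay, plausibly between 12% and 40%, the width reflecting that only one pair supports the expectation.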

Compound 4, a percentage reported as activity, at one concentration (the size of the read-out at that concentration, not a potency): 57.8%
Compound 4: middle estimate off by 32.8 percentage points, on the low side, outside the stated range (above it).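

In this assay, hydroxy to methoxy on the 3-chloro-5-hydroxyphenyl group gives a number 34.8 percentage points higher from compound 3 to compound 4 (beyond the scatter). The size of the step therefore cannot be carried from one of these cores to the other, and the step on the core of compound 1 gives no reliable guide to the step on the core of compound 3: the same change on two cores in this assay, a number 1.9 percentage points higher (within the scatter) from compound 1 to compound 2 and a number 34.8 percentage points higher (beyond the scatter) from compound 3 to compound 4, 32.9 percentage points apart, beyond the scatter of two such steps. These two pairs do not show which part of the difference between the cores sets the size of the step, nor how the change would behave on any further core.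

The compounds shown hold only hydroxy and methoxy at this place. Going by these compounds, how an ethoxy group or an amine there would read on either core remains open.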